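This account rests on a few compounds, and the source may have more. Where it says the series, first, only, none or still open, it means among the compounds named here.

Measured compounds:
- compound 1, `CCOc1cc(C)c(Cl)c2c1C(=O)C=CC2=O`: 19000 nM
- compound 2, `Cc1cc(O)c2c(c1Cl)C(=O)C=CC2=O`: 13500 nM
- compound 3, `CC(=O)Oc1cc(OC(C)=O)c2c(OC(C)=O)cc(C)c(Cl)c2c1OC(C)=O`: 52900 nM

These three values come from a functional assay on HeLa cells (Homo sapiens) for cytotoxicity, read by XTT assay, with a stated time of 24 h; a lower number here means a stronger inhibitor, a higher number a weaker inhibitor. Compound 2 gives the lowest number of the three; compound 1 is close to it, and the step of a 1.4-fold lower number from compound 1 to compound 2 (0.15 log units; within the scatter) lies within the scatter, so the two cannot be told apart. Compound 3, with its value of 52900 nM, stands furthest from compound 2, a gap beyond the scatter.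

Compound 4, `Cc1cc(O)c2c(c1Br)C(=O)C=CC2=O`, has not yet been measured. It differs from compound 2 in one place: bromo in place of chloro on an aromatic carbon. Among the measured compounds no step swaps one halogen for another; the only single-place step available, from compound 1 to compound 2, concerns a change on an oxygen and was within the scatter. Among the measured compounds shown here, there is therefore no measured step that bears directly on this change, and nothing in the data points toward a move in either direction. The expectation for compound 4 is a value near that of compound 2, with the step of a 1.0-fold lower number from compound 2 to compound 4 (0.02 log units; within the scatter) expected to stay within the scatter. Compound 4 is estimated at 13000 nM, with a range from 5000 nM to 35000 nM.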

Compound 4, half-maximal inhibitory concentration: 11300 nM
For compound 4 the middle estimate is 1.2-fold (0.06 log units) above the measured one; the range from low to high includes it.
By their numbers in this assay, from the lowest: compounds 4, 2 and 1 (each within the scatter of the next); then compound 3.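

The earlier compounds shown here offered no step at this position, the aromatic carbon ortho to a methyl group and para to a hydroxy group, so the halogen's role there could not be judged. In this assay, bromo in place of chloro gives a 1.2-fold lower number from compound 2 to compound 4 (0.08 log units; within the scatter), which means the two compounds cannot be told apart, and this core stays in the same range with either halogen at this position. Nothing available explains why the two compounds match.

As far as these compounds go, whether that holds only for these two halogens stays open, since an amine, a carboxylic acid or a longer chain at the same carbon could give a very different number. Also open, from the compounds shown here alone, is whether the same swap would read alike with ethyl on the oxygen, as in compound 1.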